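The compounds below may be only part of what the source reports. "The series", "measured", "known", "first", "only" and "open" are said of these compounds alone.

Three compounds sharing one core have been measured in a functional assay on Shh Light II cells (Mus musculus) for inhibition, read by a luciferase reporter; a higher number here means a weaker inhibitor, a lower number a stronger inhibitor:

Compound 1 `O=C(NC1CCS(=O)(=O)CC1)N1CCC(c2nc(-c3ccc4ccccc4n3)no2)CC1`: 360 nM
Compound 2 `O=C(Nc1ccccc1C(F)(F)F)N1CCC(c2nc(-c3ccc4ccccc4n3)no2)CC1`: 700 nM
Compound 3 `COc1ccccc1OC(=O)N1CCC(c2nc(-c3ccc4ccccc4n3)no2)CC1`: 250 nM

Compound 3 carries 2-methoxyphenoxy on the carbonyl carbon, where the other two carry amino groups. The measurements show a 1.4-fold lower number from compound 1 to compound 3 (0.16 log units; within the scatter), and also a 2.8-fold lower number from compound 2 to compound 3 (0.45 log units; beyond the scatter). Compound 3 therefore stands level with compound 1 within the scatter and clearly under compound 2.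

The next compound, compound 4 `O=C(NC1CCCCC1)N1CCC(c2nc(-c3ccc4ccccc4n3)no2)CC1`, has not yet been measured. It differs from compound 3 in one place: cyclohexylamino in place of 2-methoxyphenoxy on a carbonyl carbon. In words, this is cyclohexylamino in place of 2-methoxyphenoxy on a carbonyl carbon.

Both measured steps bear on this change, since each exchanges an amino group and 2-methoxyphenoxy at that same carbon. Compound 1 is the closer guide, as its 1,1-dioxothian-4-yl group is also a six-membered ring on the amino nitrogen. Among the measured compounds shown here, no measured compound carries cyclohexylamino itself. A slightly higher number in this assay is therefore expected, most likely without leaving the scatter. The expected step is a 1.7-fold higher number from compound 3 to compound 4 (0.23 log units; within the scatter). Compound 4 is estimated at 420 nM, with an expected range of 170 nM to 1000 nM.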

Compound 4, half-maximal inhibitory concentration: 57 nM
Beside the measured number, compound 4's estimate is 7.4-fold (0.87 log units) above it; measured number below the stated range.
By their numbers in this assay, from the lowest: compound 4; then compounds 3, 1 and 2 (each within the scatter of the next, the first and the last beyond it).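

In this assay, a 4.4-fold lower number from compound 3 to compound 4 (0.64 log units; beyond the scatter) shows that replacing 2-methoxyphenoxy with an amino group on the carbonyl carbon has no fixed effect: compound 1 had stayed within the scatter of compound 3 and compound 2 had a higher number, whereas compound 4 falls clearly lower. The amide-type nitrogen had also looked undiscriminating, with compound 1 and compound 2 within the scatter of each other, but cyclohexyl in place of 1,1-dioxothian-4-yl gives a 6.3-fold lower number from compound 1 to compound 4 (0.80 log units; beyond the scatter), and cyclohexyl in place of 2-(trifluoromethyl)phenyl gives a 12-fold lower number from compound 2 to compound 4 (1.09 log units; beyond the scatter), so two six-membered rings at this nitrogen are not interchangeable and compound 4 stands apart from all three others. Nothing available here accounts for these steps.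

Still open, from the compounds shown here alone, is whether the low number depends on this exact ring, which a cyclopentyl or cycloheptyl group, or an open n-hexyl chain, on the same nitrogen would test. Cyclohexyloxy on the carbonyl carbon, or an N-methyl-N-cyclohexylamino group, would show whether the amide hydrogen of compound 4 matters at all.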